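This account rests on a few compounds, and the source may have more. Where it says the series, first, only, none or still open, it means among the compounds named here.

In a functional assay on HL-60 cells (Homo sapiens) for inhibition, read by MTT assay, with a stated time of 72 h (a lower number here means a stronger inhibitor, a higher number a weaker inhibitor), compound 1 (`CC(=O)N1CCN(c2nnc3nncn3n2)CC1`) gives 14700 nM and compound 2 (`CCCNc1nnc2nncn2n1`) gives 15100 nM, two values within the usual scatter of each other. Compound 3 (`OCC(CO)(CO)Nc1nnc2nncn2n1`) is reported only as a limit, > 100000 nM. Compound 4 (`CCCCCC(=O)N1CCN(c2nnc3nncn3n2)CC1`) keeps the core of compound 1 but has butyl in place of hydrogen on a saturated chain carbon bound to a carbonyl carbon, so that acetyl becomes pentylcarbonyl: butyl in place of hydrogen on a saturated chain carbon bound to a carbonyl carbon. Within the data shown here, no two measured compounds differ in one place only, so no measured step can serve as a direct guide. Compound 1 and compound 2 carry quite different side groups, yet compound 2 at 15100 nM stays within the scatter of compound 1, so a large change is not expected. A small move toward a lower number in this assay is expected, and it may not clear the scatter: the estimated change is a 1.5-fold lower number from compound 1 to compound 4 (0.17 log units; within the scatter). For compound 4 the estimated value is 10000 nM, with an expected range from 3000 nM to 35000 nM.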

Compound 4, half-maximal inhibitory concentration: 3610 nM
For compound 4 the middle estimate is 2.8-fold (0.44 log units) above the measured one, and the stated range covers the measured number.
By their numbers in this assay, from the lowest: compound 4; then compounds 1 and 2 (each within the scatter of the next). At a limit, above all of these: compound 3.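

Read in this assay, the change from methyl to pentyl is the first change in one place only, and it gives a 4.1-fold lower number from compound 1 to compound 4 (0.61 log units; beyond the scatter). This shows that a saturated chain carbon bound to a carbonyl carbon is a place where the number responds: butyl in place of hydrogen adds only carbon, with no ring and no hydrogen-bond donors or acceptors, yet the step clears the usual scatter, though it stays modest. Nothing measured here gives a reason for this step.

A single step cannot show whether the number keeps falling with a longer chain such as octyl or whether a shorter one such as propyl already captures part of the change. It also leaves open how a phenyl ring or an amine at the end of the chain would compare with pentyl.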